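From benzyloxy to (piperidin-1-yl)methyl on a carbonyl carbon

The compounds below may be only part of what the source reports. "The series", "measured", "known", "first", "only" and "open" are said of these compounds alone.

Measured in a functional assay on the whole organism for inhibition, with Mus musculus as the target; a lower number here means that less compound is needed, a higher number that more compound is needed for the effect:
Compound 1 `Cc1ccc(C2CN(C)Cc3c(N)cccc32)cc1` gives 1.6 mg/kg
Compound 2 `CCCCNC(=O)Nc1cccc2c1CN(C)CC2c1ccc(Cl)cc1` gives 44 mg/kg
Compound 3 `CN1Cc2c(NC(=O)OCc3ccccc3)cccc2C(c2ccccc2)C1` gives about 15 mg/kg

Among these three, compound 3 stands in the middle. Its number is lower than that of compound 2 and higher than that of compound 1, and both gaps lie beyond the usual scatter. The next compound, compound 4 `CN1Cc2c(NC(=O)CN3CCCCC3)cccc2C(c2ccccc2)C1`, keeps the shared core and changes one group, with (piperidin-1-yl)methyl in place of benzyloxy on a carbonyl carbon.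

Among the measured compounds shown here, no measured pair shows a change of this kind, so the expectation rests on less direct evidence. Compound 2 (44 mg/kg) and compound 3 (about 15 mg/kg) both carry a carbonyl on an amide-type nitrogen, as compound 4 does, while compound 1 (1.6 mg/kg) does not. These two numbers are both higher than that of compound 1, although three compounds make a thin basis and their cores also differ in other places. In this assay no shift beyond the scatter, in either direction, is expected for the estimated step (a 1.3-fold higher number from compound 3 to compound 4 (0.12 log units; within the scatter)). The estimate for compound 4 is 20 mg/kg (expected range 6 mg/kg to 65 mg/kg), and the measurement will show whether it holds.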

Compound 4, dose for half-maximal effect: about 65 mg/kg
The estimate for compound 4 lay 3.3-fold (0.51 log units) below the measured number, within the range that was stated.
By their numbers in this assay, from the lowest: compound 1; then compound 3; then compounds 2 and 4 (each within the scatter of the next).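

In this assay, among the compounds shown here, the exchange of benzyloxy for (piperidin-1-yl)methyl on a carbonyl carbon gives the first direct reading at this position, a 4.3-fold higher number from compound 3 to compound 4 (0.64 log units; beyond the scatter). For the compounds shown here, the number therefore responds to the group held there, which the earlier compounds could not show since none of them forms a pair differing in one place. The two groups have the same counts of hydrogen-bond donors and acceptors and neither carries a net charge, so these counts do not separate them, and nothing available bears on why the number rises.

The change removes the oxygen on the carbonyl carbon and replaces a six-membered aromatic ring of carbon only with a six-membered non-aromatic ring with a hetero atom, and this single step cannot say which of these differences matters. A phenylethyl group on the carbonyl carbon would keep the aromatic ring without the oxygen, while a cyclohexylmethyl or morpholin-4-ylmethyl group would vary the ring, and the compounds shown do not cover any of these.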